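The source may report more compounds than this note shows. Statements on the series, on what has been measured and on what is new or still open speak of the compounds shown alone.

Three compounds have so far been measured in a functional assay on KG-1 cells (Homo sapiens) for cytotoxicity, read by luminescence and CellTiter-Glo, with a stated time of 3 days; a lower number here means a stronger inhibitor, a higher number a weaker inhibitor:

Compound 1, `N#Cc1ccc(NC(=O)c2cc(-c3ccncc3)ccc2O)cc1`, 7990 nM
Compound 2, `N#Cc1ccc(NC(=O)c2cc(Br)ccc2O)cc1`, 1290 nM
Compound 3, `N#Cc1ccc(NC(=O)c2ccc(Br)cc2O)cc1`, 1450 nM

Compound 2 and compound 3 are built from the same atoms joined differently; the difference between the two cores is not broken down here. In this assay the two give numbers that lie within the scatter of each other, so nothing separates them. Compound 1 carries pyridin-4-yl in place of bromo on an aromatic carbon, and this change gives a 6.2-fold higher number from compound 2 to compound 1 (0.79 log units; beyond the scatter).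

Compound 4, `N#Cc1ccc(NC(=O)c2ccc(-c3ccncc3)cc2O)cc1`, is not yet measured. It carries pyridin-4-yl in place of bromo on an aromatic carbon. Among the compounds with values here, this is the same kind of change as the one that leads to compound 1, but not the same change: in compound 1 the pyridin-4-yl stands meta to a large group and para to a hydroxy group, whereas in compound 4 it stands meta to a hydroxy group and para to a large group. Within the data shown here, the single measured example is the only guide. For compound 4 the author expects a step of a 4.8-fold higher number from compound 3 to compound 4 (0.68 log units; beyond the scatter), roughly the size of the earlier one, because compound 3 gives 1450 nM and the same kind of change gave a 6.2-fold higher number from compound 2 to compound 1 (0.79 log units; beyond the scatter). The different place around the pyridin-4-yl and the lack of a second example leave the expectation uncertain. Compound 4 is accordingly estimated at 7000 nM, with a range from 2500 nM to 20000 nM.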

Compound 4, half-maximal inhibitory concentration: 8840 nM
Compound 4: middle estimate off by 1.3-fold (0.10 log units), on the low side, within the range that was stated.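

In this assay, pyridin-4-yl in place of bromo on an aromatic carbon gives a 6.1-fold higher number from compound 3 to compound 4 (0.79 log units; beyond the scatter), and this step matches the one already seen on the other core: the same change on two cores in this assay, a 6.2-fold higher number (0.79 log units; beyond the scatter) from compound 2 to compound 1 and a 6.1-fold higher number (0.79 log units; beyond the scatter) from compound 3 to compound 4, 1.0-fold (0.01 log units) apart, within the scatter of two such steps The change therefore carries over between these two cores with its size intact, even though the pyridin-4-yl stands meta to a hydroxy group and para to a large group in compound 4, and meta to a large group and para to a hydroxy group in compound 1. Within the data shown here, the agreement rests on only two pairs, a single exchange of groups and a single assay, so it does not show that the step would hold on a core that differs further, and it does not explain why the number rises when the pyridin-4-yl enters.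

The compounds shown leave open whether another group in the same place, such as a phenyl ring, a pyridin-3-yl, an amine or a carboxylic acid, would give a step of similar size on both cores. As far as these compounds go, they also all keep the hydroxy group and the nitrile, so the effect of a methoxy group in place of the hydroxy group, or of a chloro group in place of the nitrile, remains unknown.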